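From pyrrolidin-2-yl to 1-acetylpiperidin-2-yl on a shared core

This account rests on a few compounds, and the source may have more. Where it says the series, first, only, none or still open, it means among the compounds named here.

In an ADME assay on MT2 cells (Homo sapiens) for cytotoxicity, read by XTT assay, with a stated time of 4 days (on this read-out lower numbers stand for higher toxicity in this test and higher numbers for lower toxicity in this test), compound 1 (`Cc1nc(C(NC(=O)C(=O)Nc2ccc(Cl)cc2)C2CCCCN2C)sc1CCO`) gives 88000 nM and compound 2 (`Cc1nc(C(NC(=O)C(=O)Nc2ccc(Cl)cc2)C2CCCN2)sc1CCO`) gives 42000 nM as the lower of the two numbers. For the measured compounds named here, the one measured step bearing on the next change is a 2.1-fold lower number from compound 1 to compound 2 (0.32 log units; beyond the scatter) and it came with pyrrolidin-2-yl in place of 1-methylpiperidin-2-yl. Compound 3 (`CC(=O)N1CCCCC1C(NC(=O)C(=O)Nc1ccc(Cl)cc1)c1nc(C)c(CCO)s1`) has 1-acetylpiperidin-2-yl in place of pyrrolidin-2-yl on a saturated chain carbon bound to an amide-type nitrogen and an aromatic carbon. Going by compound 1 at 88000 nM as the only measured piperidin-2-yl compound, a modest rise of similar size is expected (a 1.7-fold higher number from compound 2 to compound 3 (0.22 log units; within the scatter)). Compound 3 is estimated at 70000 nM in this assay (range 30000 nM to 160000 nM).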

Compound 3, half-maximal cytotoxic concentration: > 84000 nM
Compound 3 ended at the assay's limit; the forecaster's own chance of this, stated with the estimate: 20%; at least 1.2-fold (0.07 log units) between middle value and limit.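

In this assay compound 3 gives > 84000 nM, which is a limit and not a number. Putting 1-acetylpiperidin-2-yl at this place brought an at least 2.0-fold higher number from compound 2 to compound 3 (0.30 log units; that floor lies within the scatter), so this position carries the larger acylated ring with no fall in the number, though the floor of that step does not clear the usual scatter. The step with acetyl in place of methyl on an amine nitrogen in a ring, from compound 1 to compound 3, cannot be read. From the compounds shown here alone, because the step from pyrrolidin-2-yl changes both ring and nitrogen substituent, the share of each stays open; piperidin-2-yl or 1-acetylpyrrolidin-2-yl would separate them.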